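A few compounds are considered here, and "the series" means these few. Any claim that something is new, unique, unknown or untested is made for them only; others in the source may bear on it.

Measured in a functional assay on Jurkat cells (Homo sapiens) for cytotoxicity, with a stated time of 48 h; on this read-out higher numbers stand for weaker inhibition and lower numbers for stronger inhibition:
- compound 1 `CCOC(=O)CC1C(C(=O)OCC)=C(N)Oc2ccc(Br)cc21`: 57300 nM
- compound 2 `CCOC(=O)CC1C(C(=O)OCC)=C(N)Oc2c(-c3ccccc3)cccc21`: 49800 nM

Compound 1 lies within the scatter of compound 2, so neither stands apart on these numbers. Compound 3 `CCOC(=O)CC1C(C(=O)OCC)=C(N)Oc2ccc(-c3cccc4ccccc34)cc21` keeps the core of compound 1 and carries naphthalen-1-yl in place of bromo on an aromatic carbon. Among the compounds with values here, no measured step covers this change, so the expectation rests on the structural change alone and remains uncertain. In this assay, a moderate step towards stronger inhibition is expected, estimated as a 3.2-fold lower number from compound 1 to compound 3 (0.50 log units; beyond the scatter). For compound 3 the estimate is 18000 nM, with an expected range of 5000 nM to 60000 nM.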

Compound 3, half-maximal inhibitory concentration: 5830 nM
For compound 3 the middle estimate is 3.1-fold (0.49 log units) above the measured one; the range from low to high includes it.
By their numbers in this assay, from the lowest: compound 3; then compounds 2 and 1 (each within the scatter of the next).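

In this assay naphthalen-1-yl in place of bromo on this aromatic carbon gives a 9.8-fold lower number from compound 1 to compound 3 (0.99 log units; beyond the scatter) and so provides the first step beyond the scatter in the compounds shown. The position therefore accepts a far larger aromatic group than bromo, and the read-out responds to that change. No measurement at hand explains the step. From the compounds shown here alone, it remains open whether the gain depends on the fused naphthalen-1-yl or would also appear with naphthalen-2-yl or a single phenyl ring at this carbon. Going by these compounds, whether an amine or a carboxylic acid here would keep it is also open.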